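The source may hold more compounds than are shown below. What is called first, only, known or untested is meant among the compounds shown, and "the series" means these compounds.

The series is built on a shared core carrying a chain on a ring nitrogen, and the question is what happens to stomach inhibition when the group at the end of that chain is exchanged. Compound 1 `N=C(S)CCCn1nc(-c2ccccc2)ccc1=O` is measured in a functional assay on the whole organism (stomach) for inhibition, with Rattus norvegicus as the target, at a dose of 100 mg/kg by the intraduodenal route (on this read-out higher numbers stand for more inhibition at the one dose given (going by the name of the read-out) and lower numbers for less inhibition), and gives 75.6%. Compound 2 `N=C(S)CCn1ncccc1=O` gives 28.8% in this assay. Among the two measured compounds, compound 1 stands highest, and its gap to compound 2 lies beyond the scatter of repeated measurements; compound 2 differs from compound 1 in more than one place, so no single step can be read from that pair.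

Compound 3 `CNC(=O)CCn1nc(-c2ccccc2)ccc1=O` has not yet been measured. It differs from compound 1 as follows: a group of 4 heavy atoms (2 carbon, 1 nitrogen, 1 oxygen; no ring) in place of a group of 4 heavy atoms (2 carbon, 1 nitrogen, 1 sulfur; no ring), on a saturated chain carbon, two bonds along the chain from an aromatic nitrogen. Among the measured compounds shown here, no measured pair shows the effect of this exchange, so the expectation rests on compound 1 alone. The step of a number 25.6 percentage points lower from compound 1 to compound 3 (beyond the scatter) is expected to run downward by a moderate amount, beyond the scatter but leaving a substantial part of the inhibition in place. Compound 3 is therefore estimated at 50%, within a range from 20% to 80%, in this assay.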

Compound 3, a percentage reported as inhibition, in the whole organism at one dose (the size of the read-out at that dose, not a potency): 3.5%
Compound 3: middle estimate off by 46.5 percentage points, on the high side, and the stated range ends above it.
By their numbers in this assay, from the lowest: compound 3; then compound 2; then compound 1.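

In this assay, the exchange on a saturated chain carbon, two bonds along the chain from an aromatic nitrogen, puts methylcarbamoyl in place of the sulfur-bearing group of 4 heavy atoms and gives a step of a number 72.1 percentage points lower from compound 1 to compound 3 (beyond the scatter). Among the compounds shown here, this is the first single change that can be read, and it shows that inhibition at this dose depends strongly on the group at this place, since an entering group with the same count of heavy atoms, no ring and no net charge does not retain it. The entering group has oxygen instead of sulfur and one hydrogen-bond donor fewer, but nothing available shows why the inhibition falls.

The compounds shown leave open whether the sulfur or the methyl on the nitrogen of methylcarbamoyl accounts for the step, which a methylthiocarbamoyl group or an unsubstituted carbamoyl group at this place could separate. As far as these compounds go, it also remains open how a carboxylic acid or an amine at the same place would compare with compound 1 and compound 3 on the same core.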